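This account rests on a few compounds, and the source may have more. Where it says the series, first, only, none or still open, it means among the compounds named here.

Three compounds share one core and differ only in the group on an amide-type nitrogen in a ring. Compound 1 `Cc1nc(-c2nc[nH]n2)ccc1-c1cnc2c(n1)N(C(C)C)C(=O)CN2` gives 149 nM in a functional assay on PC-3 cells (Homo sapiens) for inhibition, with a stated time of 72 h; a lower number here means a stronger inhibitor, a higher number a weaker inhibitor. Compound 2 `Cc1nc(-c2nc[nH]n2)ccc1-c1cnc2c(n1)N(C1CCOCC1)C(=O)CN2` gives 102 nM. Compound 3 `CO[C@H]1CC[C@H](CN2C(=O)CNc3ncc(-c4ccc(-c5nc[nH]n5)nc4C)nc32)CC1` gives 142 nM, which places it second highest of the three numbers, though every gap among them lies within the scatter: a 1.5-fold lower number from compound 1 to compound 2 (0.16 log units; within the scatter), a 1.0-fold lower number from compound 1 to compound 3 (0.02 log units; within the scatter) and a 1.4-fold higher number from compound 2 to compound 3 (0.14 log units; within the scatter). Compound 4 `Cc1nc(-c2nc[nH]n2)ccc1-c1cnc2c(n1)N([C@H]1CC[C@H](O)CC1)C(=O)CN2` carries 4-hydroxycyclohexyl in place of (4-methoxycyclohexyl)methyl on an amide-type nitrogen in a ring. All three measured steps bear on this change: each varies the group on that same amide-type nitrogen in a ring, and none of them moved the number beyond the scatter. The next step is therefore expected to be of the same kind, a 1.1-fold lower number from compound 3 to compound 4 (0.04 log units; within the scatter), with no direction that rises above the scatter. Compound 4 is expected to give 130 nM, with a range from 60 nM to 280 nM.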

Compound 4, half-maximal inhibitory concentration: 119 nM
Compound 4: middle estimate off by 1.1-fold (0.04 log units), on the high side; low and high end bracket the measured number.
By their numbers in this assay, from the lowest: compounds 2, 4, 3 and 1 (each within the scatter of the next).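

In this assay, the change gives a 1.2-fold lower number from compound 3 to compound 4 (0.08 log units; within the scatter), even though 4-hydroxycyclohexyl has 1 hydrogen-bond donor where (4-methoxycyclohexyl)methyl has 0 and has 7 heavy atoms against 9. Compound 4 also stays close to the two smaller groups, with a 1.2-fold higher number from compound 2 to compound 4 (0.07 log units; within the scatter) and a 1.3-fold lower number from compound 1 to compound 4 (0.10 log units; within the scatter). This extends the flat picture at the amide-type nitrogen to a group with a hydroxyl, so a hydrogen-bond donor on this cyclohexyl ring, with one stereochemistry, moves the number no further than the scatter.

Going by these compounds, it remains open whether an amine or a carboxylic acid on this cyclohexyl ring would move the number beyond the scatter. No supporting measurement is available to explain why the four numbers lie so close together.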